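Dimethylphenyl for dichlorophenyl: a repeated swap, one estimate

This account rests on a few compounds, and the source may have more. Where it says the series, first, only, none or still open, it means among the compounds named here.

Of the compounds shown here, three have been measured in a functional assay on MCF7 cells (Homo sapiens) for cytotoxicity, read by MTT assay, with a stated time of 2 days; a higher number here means a weaker inhibitor, a lower number a stronger inhibitor. Compound 1 `Cc1cccc(N2CCN(CCCNc3nc(NCc4ccco4)c4ccccc4n3)CC2)c1C` gives 3310 nM, compound 2 `Clc1cccc(N2CCN(CCCNc3nc(NCc4ccco4)c4ccccc4n3)CC2)c1Cl` gives 2980 nM, and compound 3 `Clc1cccc(N2CCN(CCCCNc3nc(NCc4ccco4)c4ccccc4n3)CC2)c1Cl` gives 2970 nM. All three numbers lie within the usual scatter of one another, so no ranking among them is drawn.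

Compound 2 and compound 1 differ in one place, (2,3-dimethylphenyl in place of 2,3-dichlorophenyl on an amine nitrogen in a ring), and the step in this assay is a 1.1-fold higher number from compound 2 to compound 1 (0.05 log units; within the scatter). Compound 2 and compound 3 differ in their cores; that difference is not broken down here, and the two values show only that they sit close together.

Compound 4 `Cc1cccc(N2CCN(CCCCNc3nc(NCc4ccco4)c4ccccc4n3)CC2)c1C` has not yet been measured in this assay. It differs from compound 3 in one place, (2,3-dimethylphenyl in place of 2,3-dichlorophenyl on an amine nitrogen in a ring). The place line is the same word for word as for the pair of compound 2 and compound 1, so this is the same change, made on the core of compound 3 rather than that of compound 2. Among the compounds shown the swap occurs two times in all, and the one measured instance of it stayed within the scatter.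

For compound 4 the expected step is a 1.1-fold higher number from compound 3 to compound 4 (0.05 log units; within the scatter), because the same swap gave a 1.1-fold higher number from compound 2 to compound 1 (0.05 log units; within the scatter). Compound 4 is therefore expected to give 3300 nM, estimated to fall between 1800 nM and 6000 nM.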

Compound 4, half-maximal inhibitory concentration: 3140 nM
Compound 4: the middle estimate sits 1.1-fold (0.02 log units) above what was measured; the measured number falls inside the stated range.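

In this assay, among the compounds shown here, 2,3-dimethylphenyl in place of 2,3-dichlorophenyl on the core of compound 3 gives a 1.1-fold higher number from compound 3 to compound 4 (0.02 log units; within the scatter), so on this core too the swap leaves no step that can be read. Set beside the earlier step, the change carries from one core to the other with no gap that can be told from the scatter: the same change on two cores in this assay, a 1.1-fold higher number (0.05 log units; within the scatter) from compound 2 to compound 1 and a 1.1-fold higher number (0.02 log units; within the scatter) from compound 3 to compound 4, 1.1-fold (0.02 log units) apart, within the scatter of two such steps. This supports treating the two groups as interchangeable in this assay on these two cores only; two steps this small show neither that the swap would stay as small on a more distant core nor anything about why it is so small, and they say nothing about any other read-out.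

The compounds shown leave open whether a different group on the same ring amine nitrogen, such as an unsubstituted phenyl, a methoxyphenyl or a pyridine ring, would stay as close to these values as the 2,3-dimethylphenyl and 2,3-dichlorophenyl compounds do. They also leave open whether the swap would stay within the scatter on a core with a longer chain, or on one with an amine or a carboxylic acid in place of the group shared by all four compounds.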